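This account rests on a few compounds, and the source may have more. Where it says the series, first, only, none or still open, it means among the compounds named here.

Measured compounds in a functional assay on HepG2 cells (Homo sapiens) for antiproliferative activity, read by sulforhodamine B assay, with a stated time of 48 h; a lower number here means a stronger inhibitor, a higher number a weaker inhibitor:
- compound 1 `COc1cc(C=C(C(=O)/C=C/c2cccc(OC)c2OC)C(=O)/C=C/c2cccc(OC)c2OC)cc(OC)c1O` gives 210 nM
- compound 2 `COc1ccc(C=C(C(=O)/C=C/c2cccc(OC)c2OC)C(=O)/C=C/c2cccc(OC)c2OC)cc1O` gives 270 nM
- compound 3 `COc1ccc(OC)c(/C=C/C(=O)C(=Cc2cc(OC)c(O)c(OC)c2)C(=O)/C=C/c2cc(OC)ccc2OC)c1` gives 210 nM

Compounds 1 and 3 share the same atoms joined differently; the difference between the two cores is not broken down here. Their values in this assay sit level within the scatter, and compound 2 lies within the scatter of both.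

Among the compounds with values here, the one counted change is 3-hydroxy-4-methoxyphenyl in place of 4-hydroxy-3,5-dimethoxyphenyl on a double-bonded chain carbon bound to a double-bonded chain carbon, and it carried the step of a 1.3-fold higher number from compound 1 to compound 2 (0.11 log units; within the scatter).

Compound 4 `COc1ccc(OC)c(/C=C/C(=O)C(=Cc2ccc(OC)c(O)c2)C(=O)/C=C/c2cc(OC)ccc2OC)c1` is not yet measured. It differs from compound 3 by 3-hydroxy-4-methoxyphenyl in place of 4-hydroxy-3,5-dimethoxyphenyl on a double-bonded chain carbon bound to a double-bonded chain carbon, the same change as that from compound 1 to compound 2, at the same place.

For compound 4 the expected step is a 1.3-fold higher number from compound 3 to compound 4 (0.11 log units; within the scatter), resting on the step of a 1.3-fold higher number from compound 1 to compound 2 (0.11 log units; within the scatter) seen for the same change on the other core. The estimated value for compound 4 in this assay is 270 nM, expected between 150 nM and 500 nM.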

Compound 4, half-maximal inhibitory concentration: 470 nM
Estimate against measurement, compound 4: 1.7-fold (0.24 log units) below; the measured number falls inside the stated range.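

In this assay, 3-hydroxy-4-methoxyphenyl in place of 4-hydroxy-3,5-dimethoxyphenyl gave a 2.2-fold higher number from compound 3 to compound 4 (0.35 log units; beyond the scatter). Set beside the earlier step, the change carries across the two cores with no difference that can be told from scatter: the same change on two cores in this assay, a 1.3-fold higher number (0.11 log units; within the scatter) from compound 1 to compound 2 and a 2.2-fold higher number (0.35 log units; beyond the scatter) from compound 3 to compound 4, 1.7-fold (0.24 log units) apart, within the scatter of two such steps This rests on a single pair per core, so it does not fix the size of the step or show that the change would behave alike on any further core.

Still open, on these data alone, is how a phenyl group bearing an amine or a carboxylic acid would read at this place on the double-bonded chain carbon. Also open, as far as these compounds go, is whether the same step would hold in any assay other than this assay.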